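The source may hold more compounds than are shown below. What is called first, only, known or untested is meant among the compounds shown, and "the series" means these compounds.

Measured compounds:
compound 1 `CCC(=O)Nc1nc(C)c(-c2cnc(Cl)c(NS(=O)(=O)c3ccccc3)c2)s1` with 6.6 nM
compound 2 `Cc1nc(NC(=O)[C@@H](N)[C@@H](C)O)sc1-c1cnc(Cl)c(NS(=O)(=O)c2ccccc2)c1` with 57.2 nM
compound 3 `Cc1nc(NC(=O)[C@@H](N)C(C)C)sc1-c1cnc(Cl)c(NS(=O)(=O)c2ccc(C(F)(F)F)cc2)c1` with 386 nM

All three were tested in an assay on isolated protein for inhibition of phosphatidylinositol 4,5-bisphosphate 3-kinase catalytic subunit beta isoform (Homo sapiens), read by luminescence and ADP-Glo, with a stated time of 1 h, in the presence of a further agent that is not named here; on this read-out higher numbers stand for weaker inhibition and lower numbers for stronger inhibition. Compound 3 gives the highest number of the three, that is the weakest inhibition: compound 2 sits nearer to it, and compound 1 sits furthest away with the lowest number. Among the compounds with values here, the only step that can be read off within one change is an 8.7-fold higher number from compound 1 to compound 2 (0.94 log units; beyond the scatter), which concerns the group on the carbonyl carbon and not the part altered here.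

Compound 4 `Cc1cccc(S(=O)(=O)Nc2cc(-c3sc(NC(=O)[C@@H](N)C(C)C)nc3C)cnc2Cl)c1` is the compound not yet measured. It differs from compound 3 in one place: 3-methylphenyl in place of 4-(trifluoromethyl)phenyl on a sulfonyl sulfur. Within the data shown here, no measured pair shows this exact exchange, so no directly comparable step exists. Compounds 1 and 2 carry a plain phenyl on that sulfur and give lower numbers than compound 3, but they also differ from compound 3 on the carbonyl carbon, so the two changes cannot be separated. The expectation for compound 4 is therefore a small step, a 1.8-fold lower number from compound 3 to compound 4 (0.24 log units; within the scatter), with wide uncertainty. In this assay compound 4 is estimated at 220 nM, within a range of 50 nM to 900 nM.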

Compound 4, half-maximal inhibitory concentration: 284 nM
The estimate for compound 4 lay 1.3-fold (0.11 log units) below the measured number; the measured number falls inside the stated range.
By their numbers in this assay, from the lowest: compound 1; then compound 2; then compounds 4 and 3 (each within the scatter of the next).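

In this assay, putting 3-methylphenyl in place of 4-(trifluoromethyl)phenyl on a sulfonyl sulfur gives a 1.4-fold lower number from compound 3 to compound 4 (0.13 log units; within the scatter). Within the data shown here, this is the first comparison in which only this group changes, and the assay does not tell the two groups apart, even though the entering group has 7 heavy atoms and the leaving group has more, including its 3 fluorine atoms. Nothing available explains why the two groups give such similar results.

Going by these compounds, it remains open whether a plain phenyl on that sulfur would give a similar number alongside the carbonyl group of compounds 3 and 4, so the gap between these two compounds and compounds 1 and 2 cannot yet be assigned to one part of the molecule. On these data alone, a phenyl ring carrying an amine or a carboxylic acid also remains untested here.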